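The compounds below may be only part of what the source reports. "The series", "measured", "known", "first", "only" and "open" are said of these compounds alone.

Compound 1 `COc1ccc(N2CCN(Cc3csc(N)c3C(=O)c3ccc(Cl)cc3)CC2)cc1` sits at the start of this step. In a functional assay on CHO cells with adenosine receptor A1 (Homo sapiens) as the target, read by cAMP accumulation and immunoassay, with a stated time of 6 min, tested at 1 uM (a higher number here means a weaker effect of the compound at the concentration tested, a lower number a stronger effect), compound 1 gives -15%, which places it second highest of the three numbers gathered so far. Its nearest neighbour is compound 2 `Nc1scc(CN2CCN(c3ccc([N+](=O)[O-])cc3)CC2)c1C(=O)c1ccc(Cl)cc1`, which in this assay gives -8.3%; the step of a number 6.7 percentage points higher from compound 1 to compound 2 (within the scatter) lies within the scatter. Furthest away is compound 3 `Nc1scc(CN2CCN(c3cc(F)cc(F)c3)CC2)c1C(=O)c1ccc(Cl)cc1`, which in this assay gives -66%; the step of a number 51 percentage points lower from compound 1 to compound 3 (beyond the scatter) is large, as is the step of a number 57.7 percentage points lower from compound 2 to compound 3 (beyond the scatter).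

Compound 4 `Nc1scc(CN2CCN(CCCc3ccc(Cl)cc3)CC2)c1C(=O)c1ccc(Cl)cc1` has not yet been measured in this assay. It differs from compound 1 as follows: 3-(4-chlorophenyl)propyl in place of 4-methoxyphenyl on an amine nitrogen in a ring. The two measured steps that touch the same place, the group on the amine nitrogen in a ring, are the steps to compound 3, and both were large and downward. Neither, though, brings in a 3-(4-chlorophenyl)propyl chain; each swaps one aryl group for another, so the size and direction for compound 4 are uncertain. Taking the spread of the measured numbers as the guide, compound 4 is expected to give a step of a number 20 percentage points lower from compound 1 to compound 4 (beyond the scatter), landing near -35%, somewhere between -75% and 0% in this assay.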

Compound 4, a percentage reported as activity, at one concentration (the size of the read-out at that concentration, not a potency): -30%
For compound 4 the middle estimate is 5 percentage points below the measured one, within the range that was stated.
By their numbers in this assay, from the lowest: compound 3; then compound 4; then compounds 1 and 2 (each within the scatter of the next).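

The group on the amine nitrogen in a ring need not be an aryl group attached directly to that nitrogen: in this assay, the 3-(4-chlorophenyl)propyl group gives a number 15 percentage points lower from compound 1 to compound 4 (beyond the scatter) and a number 21.7 percentage points lower from compound 2 to compound 4 (beyond the scatter), both modest steps toward a stronger effect. That group still falls short of the 3,5-difluorophenyl group, with a number 36 percentage points higher from compound 3 to compound 4 (beyond the scatter), a large step that leaves compound 3 with the lowest number of the four and compound 4 apart from both compound 3 and the pair of compound 1 and compound 2. Nothing measured here explains these steps.

This change replaces the directly attached aryl group with a propyl chain and also brings in chlorine, so the compounds shown do not separate the part played by the chain from that played by the halogen; a plain 3-phenylpropyl group or a shorter benzyl group on the same nitrogen would bear on this. As far as these compounds go, it also remains open whether the large step to compound 3 needs both fluorines, which a plain phenyl or a 3-fluorophenyl group could test.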